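Aryl substituent change in the shared core series

The compounds below may be only part of what the source reports. "The series", "measured", "known", "first", "only" and "open" are said of these compounds alone.

Compound 3 `FC(F)(F)c1ccccc1NC(=S)N/N=C/c1ccc2ccccc2n1` sits second highest of the three numbers in a functional assay on HL-60 cells (Homo sapiens) for antiproliferative activity, read by sulforhodamine B assay, with a stated time of 72 h (on this read-out lower numbers stand for stronger inhibition and higher numbers for weaker inhibition), where compound 3 gives 13200 nM. For the measured compounds named here, its nearest neighbour is compound 1 `COc1ccccc1NC(=S)N/N=C/c1ccc2ccccc2n1`, which in this assay gives 91700 nM, and the single one-place step, a 6.9-fold lower number from compound 1 to compound 3 (0.84 log units; beyond the scatter), links the two. Far removed is compound 2 `CN(C)C(=S)N/N=C/c1ccc2ccccc2n1`, which in this assay gives 50 nM; no one-place step connects it to compound 3, so the two values are simply noted side by side.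

Compound 4 `Fc1ccccc1NC(=S)N/N=C/c1ccc2ccccc2n1` is the next member; the change from compound 3 is fluoro in place of trifluoromethyl on an aromatic carbon, the place being an aromatic carbon of the six-membered aromatic ring of carbon only, ortho to a large group. Going by the values given here, only the step from compound 1 to compound 3 touches this part of the molecule, and it swaps methoxy for trifluoromethyl rather than trifluoromethyl for fluoro, so it bears on the present step only loosely. Compound 1 and compound 3 both give numbers far above that of compound 2, and exchanging one ring substituent for another moved the number by a 6.9-fold lower number from compound 1 to compound 3 (0.84 log units; beyond the scatter). The expectation is therefore a step in this assay of about a 1.9-fold higher number from compound 3 to compound 4 (0.28 log units; within the scatter), which may still fall within the scatter. For compound 4 the estimate in this assay is 25000 nM, in the range 6000 nM to 100000 nM.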

Compound 4, half-maximal inhibitory concentration: > 100000 nM
Compound 4 ended at the assay's limit; the forecaster's own chance of this, stated with the estimate: 10%; at least 4.0-fold (0.60 log units) between middle value and limit.
By their numbers in this assay, from the lowest: compound 2; then compound 3; then compound 1. At a limit, above all of these: compound 4.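

In this assay, for the compounds shown here, compound 4 stands at a limit of the assay and not at a number: the limit of > 100000 nM in this assay, at which 1 of the 4 values shown sits. Swapping trifluoromethyl for fluoro on this aromatic carbon, ortho to a large group, gives an at least 7.5-fold higher number from compound 3 to compound 4 (0.87 log units; beyond the scatter), so this position is sensitive to more than the one exchange seen earlier, and among the three aryl compounds trifluoromethyl alone gives a value clearly separated from both others. The second new step, an at least 1.0-fold higher number from compound 1 to compound 4 (0.03 log units; that floor lies within the scatter), cannot be read as a difference, so methoxy and fluoro at this place stay unordered, and both sit on the weak side of compound 3.

Still open, as far as these compounds go, is where the true value of compound 4 lies, and with it how far fluoro really departs from methoxy and trifluoromethyl at this carbon. Also open, from the compounds shown here alone, is how a chloro group, a methyl group, a nitrile or an amine on the same aromatic carbon would compare with trifluoromethyl in this assay, and whether trifluoromethyl on a different carbon of the ring would keep the value of compound 3.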